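Removing trifluoromethyl from a weak cytotoxic compound

This account rests on a few compounds, and the source may have more. Where it says the series, first, only, none or still open, it means among the compounds named here.

Measured so far in a functional assay on PC-3 cells (Homo sapiens) for cytotoxicity, read by MTT assay, with a stated time of 72 h (on this read-out lower numbers stand for stronger inhibition and higher numbers for weaker inhibition), for two compounds
Compound 1 (`N=C(Nc1cccc(C(F)(F)F)c1)c1cc2c(-c3ccccc3)n[nH]c2cn1`) gives 19900 nM
Compound 2 (`COc1ccc(Cn2ncc3cc(C(=N)Nc4ccc(N5CCN(C)CC5)cc4)ncc32)cc1`) gives 6100 nM

Compound 1 has the higher of these two numbers, which makes it the weaker of the pair, and the gap between them lies beyond the usual scatter. Compound 3 (`N=C(Nc1ccccc1)c1cc2c(-c3ccccc3)n[nH]c2cn1`) keeps the core of compound 1 but carries hydrogen in place of trifluoromethyl on an aromatic carbon. Going by the values given here, no measured pair shows this change, so any forecast is a judgment with little support. A small move toward weaker inhibition seems likeliest, perhaps none beyond the scatter. The estimated change is a 1.3-fold higher number from compound 1 to compound 3 (0.12 log units; within the scatter) on this swap alone. The expected value for compound 3 is 26000 nM (estimated range 9000 nM to 70000 nM).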

Compound 3, half-maximal inhibitory concentration: 23000 nM
Compound 3: the middle estimate sits 1.1-fold (0.05 log units) above what was measured; the range from low to high includes it.
By their numbers in this assay, from the lowest: compound 2; then compounds 1 and 3 (each within the scatter of the next).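

In this assay, replacing trifluoromethyl with hydrogen on this aromatic carbon gives a 1.2-fold higher number from compound 1 to compound 3 (0.06 log units; within the scatter) and so produces no change that can be told apart from ordinary repeat variation. At this position, then, removing a group of four heavy atoms leaves the cytotoxic reading on the core of compound 1 effectively unchanged. Compound 1 and compound 2 differ in more than one place, so they could not isolate this group, and nothing available explains the result.

As far as these compounds go, whether another group at this position, such as an amine, a carboxylic acid or a longer chain, would shift the number beyond the scatter remains open. It is also unclear whether swapping trifluoromethyl for hydrogen would have so little effect on a different core.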